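Methoxy for methyl on the aryl of compound 2

A few compounds are considered here, and "the series" means these few. Any claim that something is new, unique, unknown or untested is made for them only; others in the source may bear on it.

Compound 2 `Cc1ccc(NC(=S)NC(=O)c2cn(-c3ccccc3)nc2-c2ccc(C)cc2)cc1` gives, in a functional assay on MCF7 cells (Homo sapiens) for inhibition, read by CCK-8 assay, with a stated time of 48 h (a higher number here means a weaker inhibitor, a lower number a stronger inhibitor), a value of 5660 nM. Compound 1 `Cc1ccc(-c2nn(-c3ccccc3)cc2C(=O)NC(=S)Nc2ccc(Cl)cc2)cc1` gives 6210 nM, and the two stand within the scatter of each other; the step of a 1.1-fold lower number from compound 1 to compound 2 (0.04 log units; within the scatter) therefore shows no real difference between them. Compound 3 `COc1ccc(-c2nn(-c3ccccc3)cc2C(=O)NC(=S)Nc2ccc(C)cc2)cc1` is the unmeasured partner of compound 2, differing by methoxy in place of methyl on an aromatic carbon. Going by the values given here, no measured step changes this same group on this same ring, so the only guide is the step from compound 1 to compound 2, a swap of a small group on the other aromatic ring, which stayed within the scatter. On that basis a change of similar size is expected in this assay, with no direction beyond the scatter, so the step for compound 3 is estimated as a 1.0-fold lower number from compound 2 to compound 3 (0.01 log units; within the scatter). Compound 3 is therefore expected to give about 5500 nM, within a range from 2500 nM to 12000 nM.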

Compound 3, half-maximal inhibitory concentration: 4630 nM
Compound 3: the middle estimate sits 1.2-fold (0.07 log units) above what was measured, within the range that was stated.
By their numbers in this assay, from the lowest: compounds 3, 2 and 1 (each within the scatter of the next).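

In this assay the replacement of 4-methylphenyl by 4-methoxyphenyl gives a 1.2-fold lower number from compound 2 to compound 3 (0.09 log units; within the scatter) and so stays within the scatter, even though the methoxy brings one more heavy atom and a hydrogen-bond acceptor to this position, para to a large group. The earlier compounds had shown such a null result only for a small swap on the other aromatic ring, so this is the first sign that a change on this ring can also leave the number where it was. No evidence is available that bears on this result.

The compounds shown leave open whether an amine, a carboxylic acid or a longer chain at this position would move the number beyond the scatter. As far as these compounds go, whether methoxy here would behave alike with chloro on the other aromatic ring also remains open.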